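Benzylsulfanyl aryl swap on the shared core

This account rests on a few compounds, and the source may have more. Where it says the series, first, only, none or still open, it means among the compounds named here.

Compound 1 `CC1=C(C(=O)Nc2ccc(Br)cc2)C(c2ccc(Cl)cc2Cl)N=C(SCc2ccccc2Cl)N1` gives 3.1% in a functional assay on the whole organism (artery, strain albino) with Rattus norvegicus as the target, with a stated time of 15 min, at a dose of 10 mg/kg by the oral route; a lower number here means less inhibition, a higher number more inhibition at the dose given (going by the name of the read-out). Compound 2 `COc1ccc(C2N=C(SCc3ccccc3Cl)NC(C)=C2C(=O)Nc2ccc(Br)cc2)cc1` gives 3.1% in the same assay; the step of no change at the digits printed from compound 1 to compound 2 (within the scatter), so compound 2 stands level with compound 1 at the digits shown. Compound 3 `COc1ccc(C2N=C(SCc3ccc(F)cc3)NC(C)=C2C(=O)Nc2ccc(Br)cc2)cc1` differs from compound 2 in 4-fluorophenyl in place of 2-chlorophenyl on a saturated chain carbon bound to a sulfur. Going by the values given here, no measured step touches this group; the only known step, no change at the digits printed from compound 1 to compound 2 (within the scatter), concerns a different part of the molecule and offers no lever either way. The expected step is therefore a number 0.1 percentage points lower from compound 2 to compound 3 (within the scatter), nothing beyond the scatter. For compound 3 the estimate is 3%, with a range from -5% to 15%.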

Compound 3, a percentage reported as inhibition, in the whole organism at one dose (the size of the read-out at that dose, not a potency): 3.6%
Compound 3: the middle estimate sits 0.6 percentage points below what was measured, within the range that was stated.
By their numbers in this assay, from the lowest: compounds 1, 2 and 3 (each within the scatter of the next).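

In this assay, the (2-chlorobenzyl)sulfanyl to (4-fluorobenzyl)sulfanyl swap gives a number 0.5 percentage points higher from compound 2 to compound 3 (within the scatter), so compound 2 and compound 3 cannot be told apart at this position. The swap exchanges chlorine for fluorine and alters the number in the group's name at once, so neither change can be read alone. No evidence accompanies this result to account for it. Open, on these data alone, is whether a sulfur substituent without an aromatic ring, such as a longer chain ending in an amine or a carboxylic acid, would give a step beyond the scatter.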